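Benzofuran piperazines at sigma-1: moving the methoxyphenyl group

The source may report more compounds than this note shows. Statements on the series, on what has been measured and on what is new or still open speak of the compounds shown alone.

Measured compounds:
- compound 1 `c1ccc(CCCN2CCN(Cc3cc4ccccc4o3)CC2)cc1`: 5.7 nM
- compound 2 `COc1ccc(CCCN2CCN(Cc3cc4ccccc4o3)CC2)cc1`: 3.1 nM

Both compounds share a core carrying a benzofuran on one nitrogen and an arylpropyl chain on the other. In an assay on brain for displacement of a labelled ligand from Sigma non-opioid intracellular receptor 1 (Rattus norvegicus), read by scintillation counting, with a stated time of 2.5 h (a higher number here means a weaker inhibitor, a lower number a stronger inhibitor), compound 2 gives 3.1 nM, and compound 1 gives 5.7 nM. The step of a 1.8-fold lower number from compound 1 to compound 2 (0.26 log units; within the scatter) is small and within the scatter, so the two values cannot be ordered.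

Compound 3 `COc1ccccc1CCCCN1CCN(Cc2cc3ccccc3o2)CC1` is the unmeasured one. It differs from compound 2 in this way: 2-methoxybenzyl in place of 4-methoxyphenyl on a saturated chain carbon, three bonds along the chain from an amine nitrogen in a ring. Among the compounds with values here, the only measured step, from compound 1 to compound 2, concerns a methoxy group alone and says nothing about moving that group or lengthening the chain, so no direction can be read from it. For compound 3 a value near that of compound 2 is therefore expected, with the step of a 1.6-fold higher number from compound 2 to compound 3 (0.21 log units; within the scatter) held within the scatter. The estimate for compound 3 in this assay is 5 nM, ranging from 1.5 nM to 20 nM.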

Compound 3, inhibition constant: 16 nM
Compound 3: middle estimate off by 3.2-fold (0.51 log units), on the low side, and the stated range covers the measured number.
By their numbers in this assay, from the lowest: compounds 2 and 1 (each within the scatter of the next); then compound 3.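

In this assay, within the data shown here, putting 2-methoxybenzyl in place of 4-methoxyphenyl gives a 5.2-fold higher number from compound 2 to compound 3 (0.71 log units; beyond the scatter) and is the first change in this set to exceed the scatter, showing that this end of the chain is not indifferent to what it carries. The comparison with the unsubstituted phenyl of compound 1 points the same way, with a 2.8-fold higher number from compound 1 to compound 3 (0.45 log units; beyond the scatter) also beyond the scatter, so compound 3 is the weakest of the three, though both steps are modest. Nothing available here accounts for this difference.

Compound 3 differs from compound 2 in two ways at once, the place of the methoxy and the extra carbon in the group, so the compounds shown cannot say which of these matters. On these data alone, how a plain benzyl group or a longer chain would behave at this position also remains open.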